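The source may hold more compounds than are shown below. What is called first, only, known or untested is meant among the compounds shown, and "the series" means these compounds.

Compound 3 `CN(C)C1(Cc2ccccc2)CCN(c2cc(C(F)(F)F)ccc2CNC(=O)Nc2cccc3ccncc23)CC1` gives 12.3 nM in an assay on CHO cells for displacement of a labelled ligand from transient receptor potential cation channel subfamily V member 1 (Homo sapiens), read by scintillation counting, with a stated time of 60 min; a lower number here means a stronger inhibitor, a higher number a weaker inhibitor. Among the three compounds measured so far, this is the highest number. Its nearest neighbour is compound 2 `CN(C)C1(Cc2ccccc2)CCN(c2cc(C(F)(F)F)ccc2CNC(=O)Nc2ccc3ccncc3c2)CC1`, which gives 7.33 nM in this assay; the step of a 1.7-fold higher number from compound 2 to compound 3 (0.22 log units; within the scatter) is within the scatter, so the two cannot be told apart. The furthest is compound 1 `CN(C)C1(Cc2ccccc2)CCN(c2cc(C(F)(F)F)ccc2CNC(=O)Nc2cccc3ccc(O)cc23)CC1`, which gives 0.46 nM in this assay; here the steps of a 27-fold higher number from compound 1 to compound 3 (1.43 log units; beyond the scatter) and a 16-fold higher number from compound 1 to compound 2 (1.20 log units; beyond the scatter) are both large and beyond the scatter.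

The next compound, compound 4 `CN(C)C1(Cc2ccccc2)CCN(c2cc(C(F)(F)F)ccc2CNC(=O)Nc2cccc3ncccc23)CC1`, is made from compound 3 by the change (quinolin-5-yl in place of isoquinolin-8-yl on an amide-type nitrogen). Among the compounds with values here, the only measured step that bears on it directly is the one between compound 2 and compound 3, where the two groups likewise had the same atoms joined differently and the result stayed within the scatter. The large steps from compound 1 involve a hydroxyl group that neither compound 3 nor compound 4 carries, so they say little about this change. The expectation for compound 4 is therefore a step of a 1.2-fold lower number from compound 3 to compound 4 (0.09 log units; within the scatter) in this assay, which is no change beyond the scatter. Compound 4 is thus estimated at 10 nM, with a range from 3 nM to 35 nM.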

Compound 4, inhibition constant: 10.8 nM
The estimate for compound 4 lay 1.1-fold (0.03 log units) below the measured number, within the range that was stated.
By their numbers in this assay, from the lowest: compound 1; then compounds 2, 4 and 3 (each within the scatter of the next).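

In this assay, quinolin-5-yl on the amide-type nitrogen gives a 1.1-fold lower number from compound 3 to compound 4 (0.06 log units; within the scatter) and a 1.5-fold higher number from compound 2 to compound 4 (0.17 log units; within the scatter), so compound 2, compound 3 and compound 4 cannot be told apart, even though their groups have the same atoms joined in three different ways. The large gap to the hydroxyl-bearing group remains with this third arrangement, at a 23-fold higher number from compound 1 to compound 4 (1.37 log units; beyond the scatter), so none of the three nitrogen-containing ring groups shown comes close to compound 1. Nothing measured here explains why these three compounds fall together or why compound 1 stands apart.

The compounds shown leave open whether a hydroxyl group on the quinolin-5-yl ring would bring the number towards that of compound 1, and whether a plain naphthalen-1-yl group without the hydroxyl would lose the advantage of compound 1. Also open, as far as these compounds go, is how an amino group or a methoxy group in place of that hydroxyl would read in this assay.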